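The source may report more compounds than this note shows. Statements on the series, on what has been measured and on what is new or still open speak of the compounds shown alone.

Working notes on the series. Compound 1 `CC[C@H](C)[C@H](N)CN(C(=O)[C@@H]1C[C@H]1c1ccccc1)c1ccc(-c2ccc(Oc3ccccc3)cc2)cc1` is the reference point: in a functional assay for agonist activity at G protein-coupled receptor 88 (Homo sapiens), read by HTRF and cAMP accumulation (on this read-out higher numbers stand for an effect only at larger amounts of compound and lower numbers for an effect already at smaller amounts), compound 1 gives 94 nM. Compound 2 `CC[C@H](C)[C@H](N)CN(C(=O)[C@@H]1C[C@H]1c1ccccc1)c1ccc(-c2ccc(CO)cc2)cc1` differs from it only in the group on the outer aromatic ring, and in this assay compound 2 gives 1100 nM. Among the measured compounds shown here, the step of a 12-fold higher number from compound 1 to compound 2 (1.07 log units; beyond the scatter) is the only measured step in the set. For the measured compounds named here, on the numbers so far, compound 2 stands as the higher of the two, with compound 1 as its only neighbour.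

Compound 3 `CC[C@H](C)[C@H](N)CN(C(=O)[C@@H]1C[C@H]1c1ccccc1)c1ccc(-c2ccc(NS(C)(=O)=O)cc2)cc1` changes the same outer position once more: methanesulfonamido in place of hydroxymethyl on an aromatic carbon. Going by the values given here, no measured step covers this exact exchange. Among the compounds with values here, the one step that bears on it, a 12-fold higher number from compound 1 to compound 2 (1.07 log units; beyond the scatter), shows that this position tolerates a large change in number, and that removal of phenoxy in favour of a small group carrying a hydrogen-bond donor gave the higher number. Methanesulfonamido is again a small group with a hydrogen-bond donor, so the expected step of a 1.4-fold higher number from compound 2 to compound 3 (0.13 log units; within the scatter) is small, within or near the scatter, with direction uncertain. Compound 3 is expected to give 1500 nM in this assay, with a range of 400 nM to 6000 nM.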

Compound 3, half-maximal effective concentration: 1200 nM
Estimate against measurement, compound 3: 1.3-fold (0.10 log units) above, within the range that was stated.
By their numbers in this assay, from the lowest: compound 1; then compounds 2 and 3 (each within the scatter of the next).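

In this assay the step of a 1.1-fold higher number from compound 2 to compound 3 (0.04 log units; within the scatter) shows that hydroxymethyl and methanesulfonamido on this aromatic carbon, para to a large group, cannot be told apart, even though the entering group has 5 heavy atoms against 2 and brings in sulfur and 2 double bonds outside aromatic rings. The step of a 13-fold higher number from compound 1 to compound 3 (1.11 log units; beyond the scatter) is a second replacement of phenoxy that ends far from compound 1, so the higher number is not tied to hydroxymethyl alone; among these three compounds, the two whose group has no ring sit together and away from compound 1, and none goes against this. No measurement at hand accounts for either step.

The compounds shown leave open whether the lower number of compound 1 depends on the ring of phenoxy or on its ether oxygen, a question that benzyl or phenylamino at this position would help to separate. From the compounds shown here alone, it is also open whether a carboxylic acid, a primary amine or a longer chain such as 2-hydroxyethyl would stay with compound 2 and compound 3 or move towards compound 1.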